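Predicting an ACAT inhibitor with a methoxy-methylpyridine ring

A few compounds are considered here, and "the series" means these few. Any claim that something is new, unique, unknown or untested is made for them only; others in the source may bear on it.

Compound 1 `CSc1nc(C)nc(SC)c1NC(=O)N(Cc1ccc(Oc2ccc(F)cc2)cc1)C1CCCCCC1`: 56 nM
Compound 2 `CSc1nc(C)cc(Cl)c1NC(=O)N(Cc1ccc(Oc2ccc(F)cc2)cc1)C1CCCCCC1`: 12 nM

In an assay for inhibition of acyl-CoA:cholesterol acyltransferase (Oryctolagus cuniculus), using microsomes (on this read-out higher numbers stand for weaker inhibition and lower numbers for stronger inhibition), compound 2 gives 12 nM, the lowest number of the two, with compound 1 giving a higher number by a 4.7-fold lower number from compound 1 to compound 2 (0.67 log units; beyond the scatter). Compound 3 `COc1nc(C)ccc1NC(=O)N(Cc1ccc(Oc2ccc(F)cc2)cc1)C1CCCCCC1` differs from compound 2 in one place: a group of 9 heavy atoms (7 carbon, 1 nitrogen, 1 oxygen; one six-membered aromatic ring with 1 hetero atom) in place of a group of 10 heavy atoms (7 carbon, 1 nitrogen, 1 sulfur, 1 chlorine; one six-membered aromatic ring with 1 hetero atom), on an amide-type nitrogen. Among the measured compounds shown here, only one measured step touches this part of the molecule, the change from compound 1 to compound 2, which altered the same aromatic ring and produced a step of a 4.7-fold lower number from compound 1 to compound 2 (0.67 log units; beyond the scatter); it shows that changes here can matter, but it does not test a methoxy group, so it bears on the new step only loosely. A change of this kind is expected to move this assay by roughly the same order, most likely toward a higher number, so compound 3 is estimated at a 2.5-fold higher number from compound 2 to compound 3 (0.40 log units; beyond the scatter) relative to compound 2. Compound 3 is therefore expected to give about 30 nM, within a range of 8 nM to 120 nM.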

Compound 3, half-maximal inhibitory concentration: 39 nM
Beside the measured number, compound 3's estimate is 1.3-fold (0.11 log units) below it, and the stated range covers the measured number.
By their numbers in this assay, from the lowest: compound 2; then compounds 3 and 1 (each within the scatter of the next).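

In this assay, putting the 2-methoxy-6-methylpyridin-3-yl group on the amide-type nitrogen gives a 3.3-fold higher number from compound 2 to compound 3 (0.51 log units; beyond the scatter), so a change of ring at this place can raise the number as well as lower it, and compound 2 keeps the lowest number of the three. The same group set against the ring of compound 1 gives a 1.4-fold lower number from compound 1 to compound 3 (0.16 log units; within the scatter), so two rings with different atoms can read alike on this assay. Nothing available explains either result.

Going by these compounds, compound 2 and compound 3 differ in several atoms of the ring at once, so it stays open whether the loss of the chlorine or the exchange of sulfur for oxygen accounts for the step. On these data alone, how an ethoxy group or an amine would read in place of the methoxy group also stays open.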